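The compounds below may be only part of what the source reports. "The series", "measured", "known", "first", "only" and "open" are said of these compounds alone.

Compound 1 `COc1cc2nnc(C(N)=O)c(Nc3ccc(C)cc3F)c2cc1N1CCN(C)CC1` — 87000 nM
Compound 2 `COc1cc2nnc(C(N)=O)c(Nc3ccc(C)cc3F)c2cc1N1CCN(C(C)C)CC1` — 40000 nM

In a physicochemical assay for solubility (a higher number here means a more soluble compound, a lower number a less soluble compound), compound 2 gives 40000 nM, the lower of the two numbers; compound 1 gives 87000 nM. Among the compounds with values here, the only measured step, a 2.2-fold lower number from compound 1 to compound 2 (0.34 log units; beyond the scatter), arose from isopropyl in place of methyl on an amine nitrogen in a ring. Compound 3 `COc1cc2nnc(C(N)=O)c(Nc3ccc(C)cc3F)c2cc1N1CCCN(C)CC1` differs from compound 2 by 4-methyl-1,4-diazepan-1-yl in place of 4-isopropylpiperazin-1-yl on an aromatic carbon. Within the data shown here, the methyl on the ring nitrogen returns while the ring grows by one atom; no measured step covers such a ring change. Compound 3 is therefore expected near 70000 nM, between 30000 nM and 160000 nM, a modest rise, a 1.8-fold higher number from compound 2 to compound 3 (0.24 log units; within the scatter), because compound 1 with its methyl gave 87000 nM.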

Compound 3, solubility: 54000 nM
Compound 3: the middle estimate sits 1.3-fold (0.11 log units) above what was measured, within the range that was stated.
By their numbers in this assay, from the lowest: compounds 2, 3 and 1 (each within the scatter of the next, the first and the last beyond it).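

In this assay, 4-methyl-1,4-diazepan-1-yl on this aromatic carbon stays within the scatter of both piperazines: a 1.4-fold higher number from compound 2 to compound 3 (0.13 log units; within the scatter) when it replaces 4-isopropylpiperazin-1-yl, and a 1.6-fold lower number from compound 1 to compound 3 (0.21 log units; within the scatter) when it replaces 4-methylpiperazin-1-yl. The position thus tolerates a seven-membered ring in place of a six-membered one without a step beyond the scatter, which the earlier pair, differing only in the group on the ring nitrogen, could not show. Nothing at hand explains this result. Still open, as far as these compounds go, is whether a morpholine or an open-chain amine on this carbon would stay in the same range, and what isopropyl on the diazepane nitrogen would give.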